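The compounds below may be only part of what the source reports. "The series", "measured", "known", "first", "only" and "open" are said of these compounds alone.

Compound 1 `Cc1ccc(-c2cc(C(=O)N[C@H](C)c3ccc(C(F)(F)F)nc3)cc(C(C)(C)O)c2)nc1`: 95.2%
Compound 2 `Cc1ccc(-c2cc(C(=O)N[C@H](C)c3nc(C)no3)cc(-c3ncccc3F)c2)nc1`: 99.6%
Compound 3 `Cc1ccc(-c2cc(C(=O)N[C@@H](C)c3nnc[nH]3)cc(-c3ncccc3F)c2)nc1`: 98.8%

In an ADME assay on a cell-free system (plasma, Rattus norvegicus) for protein binding, compound 2 has the lowest unbound fraction of the three measured compounds. The change to compound 4 `Cc1ccc(-c2cc(C(=O)N[C@H](C)c3ccc(C(F)(F)F)[n+]([O-])c3)cc(-c3ncccc3F)c2)nc1` is a group of 11 heavy atoms (6 carbon, 1 nitrogen, 1 oxygen, 3 fluorine; one six-membered aromatic ring with 1 hetero atom) in place of a group of 6 heavy atoms (3 carbon, 2 nitrogen, 1 oxygen; one five-membered aromatic ring with 3 hetero atoms), on a saturated chain carbon bound to an amide-type nitrogen and a saturated chain carbon. Among the measured compounds shown here, the 3-methyl-1,2,4-oxadiazol-5-yl group leaves, and no measured compound carries the entering group. For the measured compounds named here, the only measured step at this place, a 3.0-fold higher unbound fraction from compound 2 to compound 3 (0.48 log units; beyond the scatter), is modest and starts from the same compound. A step of similar size and the same direction is therefore expected, with the expected step being a 2.5-fold higher unbound fraction from compound 2 to compound 4 (0.40 log units; beyond the scatter). The estimated value for compound 4 is 99% (range 97.5% to 99.7%).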

Compound 4, plasma protein binding: 95.2%
Beside the measured number, compound 4's estimate is 4.8-fold (0.68 log units) (unbound fraction) below it, and the stated range ends above it.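

In this assay, replacing the 3-methyl-1,2,4-oxadiazol-5-yl group at this place gives a 12-fold higher unbound fraction from compound 2 to compound 4 (1.08 log units; beyond the scatter), a large step where the earlier one, a 3.0-fold higher unbound fraction from compound 2 to compound 3 (0.48 log units; beyond the scatter), was modest. Among the compounds shown here, the place therefore allows a much wider range of unbound fraction than the earlier compounds showed, and the entering group reaches it with no hydrogen-bond donors and a larger heavy-atom count. Nothing available explains the size of this step.

The shown compounds do not separate the contributions of the trifluoromethyl group and the ring oxygen within the entering group. On these data alone, how a carboxylic acid or an amine at this place would compare remains open.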